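Swapping a Para Substituent on the Benzyl Amide

A few compounds are considered here, and "the series" means these few. Any claim that something is new, unique, unknown or untested is made for them only; others in the source may bear on it.

Measured compounds:
compound 1, `N[C@H]1CC[C@H](Nc2c(C(=O)NCc3ccc(Cl)cc3)nc(Br)c3cccnc23)CC1`, "not determined" (no result reported) in a functional assay on MCF7 cells (Homo sapiens) for cytotoxicity, read by MTT assay, with a stated time of 72 h; on this read-out higher numbers stand for weaker inhibition and lower numbers for stronger inhibition
compound 2, `C[C@@H](Nc1c(C(=O)NCc2ccc(F)cc2)nc(Br)c2cccnc12)c1ccccc1`, "not determined" (no result reported) in this assay
compound 3, `NCCNc1c(C(=O)NCc2ccc(F)cc2)nc(Br)c2cccnc12`, 6000 nM

Three compounds share the same core and have been put through this assay, yet only one of them carries a number. Among the measured compounds shown here, compound 1 has no result reported, and compound 2 stands in the same position, so no comparison between measured partners can be drawn, and no step from one measured compound to another is available. Compound 3 is the only anchor, and in this assay compound 3 gives 6000 nM.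

The unmeasured compound 4 is `CN(C)c1ccc(CNC(=O)c2nc(Br)c3cccnc3c2N[C@H]2CC[C@H](N)CC2)cc1`. It differs from compound 1 by a single change: dimethylamino in place of chloro on an aromatic carbon. Since compound 1 itself has no number, the size and direction of this step cannot be read from the data; what is shown leaves any change of this kind as a matter of expectation alone, and no movement beyond the scatter can be asserted in this assay.

Compound 4 is expected to land near 4000 nM, with a range from 800 nM to 20000 nM, because compound 3 gives 6000 nM as the sole anchor.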

Compound 4, half-maximal inhibitory concentration: 5000 nM
Beside the measured number, compound 4's estimate is 1.3-fold (0.10 log units) below it; the range from low to high includes it.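

No step can be read from compound 1 to compound 4, as compound 1 stands at "not determined" (no result reported) in this assay and offers no number for comparison. From the compounds shown here alone, what dimethylamino in place of chloro does to this read-out stays open. Nothing further shown bears on this result.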